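Cyclobutyl for cyclopropyl on a fluoro and a chloro core

The source may hold more compounds than are shown below. What is called first, only, known or untested is meant among the compounds shown, and "the series" means these compounds.

Measured compounds:
Compound 1, `O=S1(=O)NC(NC2CC2)=Nc2ccc(F)cc21`: > 300 uM
Compound 2, `O=S1(=O)NC(NC2CCC2)=Nc2ccc(F)cc21`: 71.8 uM
Compound 3, `O=S1(=O)N=C(NC2CC2)Nc2ccc(Cl)cc21`: 190 uM

Of the compounds shown here, three have been measured in a functional assay (aorta) with Rattus norvegicus as the target; a higher number here means that more compound is needed for the effect, a lower number that less compound is needed. For compound 1 the value is a limit of the assay, > 300 uM, and not a number. Compound 2 gives 71.8 uM and compound 3 gives 190 uM. Among the measured compounds shown here, the one change that can be counted between measured compounds is cyclobutyl in place of cyclopropyl on an amine nitrogen; it brings an at least 4.1-fold lower number from compound 1 to compound 2 (0.62 log units; beyond the scatter), and the step is known only as a lower bound because compound 1 sits at the limit of > 300 uM in this assay, at which 1 of the 3 values shown sits. For the measured compounds named here, how the core of compound 3 differs from that of compound 1 is not broken down here; their two values show only that compound 3 yields a number where compound 1 yields a limit.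

Compound 4, `O=S1(=O)N=C(NC2CCC2)Nc2ccc(Cl)cc21`, is not yet measured. It differs from compound 3 by cyclobutyl in place of cyclopropyl on an amine nitrogen, the same change that leads from compound 1 to compound 2, with the amine nitrogen in identical surroundings in both pairs. On the fluoro core this change gave an at least 4.1-fold lower number from compound 1 to compound 2 (0.62 log units; beyond the scatter), and a step of similar size is expected on the chloro core, so that compound 4 is estimated to give a 4.2-fold lower number from compound 3 to compound 4 (0.63 log units; beyond the scatter) in this assay. On that basis compound 4 is expected to come in at 45 uM, with a likely range from 15 uM to 130 uM.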

Compound 4, concentration for half-maximal effect: 34.9 uM
Compound 4: the middle estimate sits 1.3-fold (0.11 log units) above what was measured, and the stated range covers the measured number.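

In this assay, cyclobutyl in place of cyclopropyl on an amine nitrogen also lowers the number on the chloro core, giving a 5.4-fold lower number from compound 3 to compound 4 (0.74 log units; beyond the scatter) on this second core of the series. Both pairs point the same way and both steps lie beyond the scatter, which shows that the direction of the change held on the two cores tested, but not that the size of the step is the same or that the direction would hold on any further core: the same change on two cores in this assay, an at least 4.1-fold lower number (0.62 log units; beyond the scatter) from compound 1 to compound 2 and a 5.4-fold lower number (0.74 log units; beyond the scatter) from compound 3 to compound 4; the limit leaves it open whether they differ. Compound 1 gives > 300 uM in this assay, and this is a limit of the assay and not a number: the limit of > 300 uM in this assay, at which 1 of the 4 values shown sits.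

The compounds shown leave open whether a larger ring such as cyclopentyl or cyclohexyl on the same amine nitrogen would lower the number further, and how an open chain such as isopropyl or butyl would compare with cyclobutyl. They also leave open whether the same change would go the same way on a core carrying bromo or methyl where these cores carry fluoro or chloro.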